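The compounds below may be only part of what the source reports. "The series", "measured", "known", "first", "only" and "open" are said of these compounds alone.

Compound 1 `CNC(=O)c1cc(Oc2ccc(NC(=O)c3cc4cccnc4n(-c4ccccc4)c3=O)cc2)ccn1` gives 200 nM in a functional assay on A549 cells (Homo sapiens) for antiproliferative activity, read by MTT assay, with a stated time of 72 h; on this read-out higher numbers stand for weaker inhibition and lower numbers for stronger inhibition. Compound 2 `CNC(=O)c1cc(Oc2ccc(NC(=O)c3cc4cccnc4n(-c4ccc(OC)cc4)c3=O)cc2)ccn1` gives 3110 nM in this assay. Among the compounds with values here, the one step between measured compounds, a 16-fold higher number from compound 1 to compound 2 (1.19 log units; beyond the scatter), is methoxy in place of hydrogen on an aromatic carbon. On the two numbers available, compound 2 stands highest, with compound 1 as its nearest neighbour at a lower number.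

Compound 3 `CCCNC(=O)c1cc(Oc2ccc(NC(=O)c3cc4cccnc4n(-c4ccc(OC)cc4)c3=O)cc2)ccn1` is not yet measured. It differs from compound 2 by ethyl in place of hydrogen on a saturated chain carbon bound to an amide-type nitrogen. Neither measured compound carries this change: the step from compound 1 to compound 2 concerns a different group at a different place and so does not bear on the present change. Within the data shown here, no measured step gives a direction for this assay here, and the working assumption is a step of no more than the usual scatter, in either direction. Compound 3 is therefore expected at about 3000 nM, between 1000 nM and 9000 nM. The step this implies, a 1.0-fold lower number from compound 2 to compound 3 (0.02 log units; within the scatter), is an expectation only, not a measurement.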

Compound 3, half-maximal inhibitory concentration: 820 nM
Estimate against measurement, compound 3: 3.7-fold (0.56 log units) above, outside the stated range (below it).
By their numbers in this assay, from the lowest: compound 1; then compound 3; then compound 2.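

The saturated chain carbon bound to an amide-type nitrogen, unchanged between compound 1 and compound 2, now proves to be a place where a change registers in this assay: methylcarbamoyl to propylcarbamoyl gives a 3.8-fold lower number from compound 2 to compound 3 (0.58 log units; beyond the scatter). The direction is informative, since the added ethyl does not raise the number at this place but lowers it, so a chain longer than methyl is accommodated here, at least with the methoxy group present on the shared core. Nothing at hand accounts for the size or direction of this step, and no supporting measurement bears on it.

The compounds shown leave open whether the same change would carry over to the core of compound 1, which lacks the methoxy group, since this step has been read only in the methoxy-bearing setting. They also leave open how the number runs along this chain, whether an ethyl or butyl chain, a branched isopropyl, a cyclopropyl ring, or a chain ending in an amine or a carboxylic acid would follow propyl or break from it.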